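The compounds below may be only part of what the source reports. "The series", "measured", "known", "first", "only" and "open" are said of these compounds alone.

Measured in a functional assay on A549 cells (Homo sapiens) for antiproliferative activity, read by CCK-8 assay, with a stated time of 72 h; on this read-out lower numbers stand for stronger inhibition of growth and higher numbers for weaker inhibition of growth:
- compound 1 `CC[C@@H]1C(=O)N(C)c2cnc(-n3ccc4cc(C(N)=O)ccc43)nc2N1C1CCCC1`: 4350 nM
- compound 2 `CCC1C(=O)N(C)c2cnc(-n3ccc4cc(C(=O)NC(C)C)ccc43)nc2N1c1ccn(C)n1`: 22000 nM
- compound 3 `CCCCNS(=O)(=O)c1ccc(Nc2ncc3c(n2)N(C2CCCC2)[C@H](CC)C(=O)N3C)cc1`: 477 nM

Compound 1 sits in the middle of these three numbers, with compound 2 clearly higher and compound 3 clearly lower. Still unmeasured is compound 4 `CCCNC(=O)c1ccc2c(ccn2-c2ncc3c(n2)N(C2CCCC2)[C@H](CC)C(=O)N3C)c1`, which differs from compound 1 in one place: propyl in place of hydrogen on an amide-type nitrogen. Among the measured compounds shown here, no measured pair shows this change alone, so the expectation is loose. In this assay, no step beyond the scatter is expected, with a slight lean towards stronger growth inhibition. The estimated step is a 1.5-fold lower number from compound 1 to compound 4 (0.16 log units; within the scatter). The expected value for compound 4 is 3000 nM, within a range of 800 nM to 11000 nM.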

Compound 4, concentration for 50% growth inhibition: 1640 nM
The estimate for compound 4 lay 1.8-fold (0.26 log units) above the measured number, and the stated range covers the measured number.
By their numbers in this assay, from the lowest: compound 3; then compound 4; then compound 1; then compound 2.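

Among the compounds shown here, this pair isolates the amide nitrogen for the first time: in this assay, propyl in place of the amide hydrogen gives a 2.7-fold lower number from compound 1 to compound 4 (0.42 log units; beyond the scatter), a modest gain in growth inhibition. This nitrogen therefore tolerates a propyl chain, and the amide hydrogen removed here is not needed for this activity. Nothing measured here explains the shift.

As far as these compounds go, whether a longer chain such as hexyl, or a propyl chain ending in an amine or a carboxylic acid, would lower the number further remains open. This single pair also cannot show whether the step carries over to other groups on the shared core.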